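Cytotoxicity of a methoxycarbonyl variant in a nucleoside series

The source may hold more compounds than are shown below. What is called first, only, known or untested is meant among the compounds shown, and "the series" means these compounds.

Of the compounds shown here, three sharing one core have been tested in a functional assay on MT4 cells (Homo sapiens); a lower number here means that less compound is tolerated, a higher number that more compound is tolerated. Compound 1 `CCOC(=O)CNC(=O)NC1=CS(=O)(=O)O[C@@]12[C@@H](CO[Si](C)(C)C(C)(C)C)O[C@@H](n1cc(C)c(=O)n(C)c1=O)[C@@H]2O[Si](C)(C)C(C)(C)C` gives 3780 nM. Compound 2 `Cc1cn([C@@H]2O[C@H](CO[Si](C)(C)C(C)(C)C)[C@@]3(OS(=O)(=O)C=C3NCC(=O)C(N)=O)[C@H]2O[Si](C)(C)C(C)(C)C)c(=O)n(C)c1=O` gives 9590 nM. Compound 3 `CC(=O)NC1=CS(=O)(=O)O[C@@]12[C@@H](CO[Si](C)(C)C(C)(C)C)O[C@@H](n1cc(C)c(=O)n(C)c1=O)[C@@H]2O[Si](C)(C)C(C)(C)C` gives 10700 nM, the highest of the three numbers, although its gap to compound 2 lies within the scatter, so the two cannot be ranked against each other.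

Compound 4 `COC(=O)NC1=CS(=O)(=O)O[C@@]12[C@@H](CO[Si](C)(C)C(C)(C)C)O[C@@H](n1cc(C)c(=O)n(C)c1=O)[C@@H]2O[Si](C)(C)C(C)(C)C` differs from compound 3 in one place: methoxy in place of methyl on a carbonyl carbon. Read one bond further out, acetamido becomes (methoxycarbonyl)amino.

Among the measured compounds shown here, two measured steps touch the same region. The step of a 2.8-fold higher number from compound 1 to compound 3 (0.45 log units; beyond the scatter) replaced a larger group on that carbonyl carbon by methyl and moved the number modestly upward. The step of a 1.1-fold higher number from compound 2 to compound 3 (0.05 log units; within the scatter) changed the group on the amine nitrogen and stayed within the scatter. Adding a single oxygen to make methoxy is a smaller change than either, so the expected step of a 1.1-fold lower number from compound 3 to compound 4 (0.05 log units; within the scatter) in this assay is small, with no clear direction beyond the scatter.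

Compound 4 is therefore estimated at 9500 nM, within a range from 4000 nM to 22000 nM.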

Compound 4, half-maximal cytotoxic concentration: 29900 nM
Estimate against measurement, compound 4: 3.1-fold (0.50 log units) below, and the stated range ends below it.
By their numbers in this assay, from the lowest: compound 1; then compounds 2 and 3 (each within the scatter of the next); then compound 4.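

In this assay, putting methoxy in place of methyl on the carbonyl carbon proves to be no minor edit: a 2.8-fold higher number from compound 3 to compound 4 (0.45 log units; beyond the scatter) is a shift of the same printed size as replacing the much larger ((ethoxycarbonyl)methyl)amino group with methyl, a 2.8-fold higher number from compound 1 to compound 3 (0.45 log units; beyond the scatter) in the same direction. Compound 4 also stands clear of the other two compounds, with a 3.1-fold higher number from compound 2 to compound 4 (0.49 log units; beyond the scatter) and a 7.9-fold higher number from compound 1 to compound 4 (0.90 log units; beyond the scatter) as the further steps, so at this place one added oxygen separates compounds that the earlier changes could not. No measurement shown here explains this rise.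

The compounds shown leave open whether ethoxy, a longer alkoxy chain or a plain amino group on the same carbonyl carbon would carry the number further up or bring it back down.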